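Iodo in place of phenyl on the shared core

A few compounds are considered here, and "the series" means these few. Any claim that something is new, unique, unknown or untested is made for them only; others in the source may bear on it.

Going by the values given here, compound 3 `Cc1cc(-c2ccccc2)c2ncc(CSCCc3ccccc3)n2c1` gives 20 ug/mL in an ADME assay on HEL cells (Homo sapiens) for cytotoxicity, with a stated time of 3 days (on this read-out lower numbers stand for higher toxicity in this test and higher numbers for lower toxicity in this test), the lowest of the three numbers so far: compound 1 `COc1cccc(-c2cc(C)cn3c(CSCCc4ccccc4)cnc23)c1` gives 100 ug/mL and compound 2 `Cc1cc(-c2cccs2)c2ncc(CSCCc3ccccc3)n2c1` gives 100 ug/mL, so compound 3 is the most cytotoxic of the measured set. Compound 4 `Cc1cc(I)c2ncc(CSCCc3ccccc3)n2c1` differs from compound 3 by iodo in place of phenyl on an aromatic carbon. Among the compounds with values here, no measured step covers this exact change; only the two steps that end at compound 3 touch the same aromatic carbon, and both show compound 3 with the lowest number: a 5.0-fold lower number from compound 1 to compound 3 (0.70 log units; beyond the scatter) and a 5.0-fold lower number from compound 2 to compound 3 (0.70 log units; beyond the scatter). Because compound 1 and compound 2 sit higher after a 5.0-fold lower number from compound 1 to compound 3 (0.70 log units; beyond the scatter) and a 5.0-fold lower number from compound 2 to compound 3 (0.70 log units; beyond the scatter), a move back upward is expected for compound 4, roughly a 2.5-fold higher number from compound 3 to compound 4 (0.40 log units; beyond the scatter). Compound 4 is therefore estimated at 50 ug/mL, within 20 ug/mL to 100 ug/mL.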

Compound 4, minimum cytotoxic concentration: >= 4 ug/mL
Compound 4 was reported as a limit; the forecaster's own chance of this, stated with the estimate: 20%; the middle value is on the limit's open side.
By their numbers in this assay, from the lowest: compound 3; then compounds 1 and 2 (each within the scatter of the next).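

In this assay compound 4 gives >= 4 ug/mL, a limit and not a number, so its steps from compound 1, compound 2 and compound 3 cannot be read. From the compounds shown here alone, whether iodo on the shared core gives a higher or lower number than phenyl, thiophen-2-yl or 3-methoxyphenyl stays open.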